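Swapping the benzylic amine in a quinazoline urea series

The compounds below may be only part of what the source reports. "The series", "measured", "known", "first", "only" and "open" are said of these compounds alone.

Measured so far in a functional assay on A-431 cells (Homo sapiens) for antiproliferative activity, read by MTT assay, with a stated time of 72 h; a higher number here means a weaker inhibitor, a lower number a stronger inhibitor:
compound 1 `CN1CCN(Cc2ccc(NC(=O)Nc3ccc4ncnc(Nc5cccc(C(F)(F)F)c5)c4c3)cc2)CC1` gives 2410 nM;
compound 2 `CCN(CC)Cc1ccc(NC(=O)Nc2ccc3ncnc(Nc4cccc(C(F)(F)F)c4)c3c2)cc1` gives 3980 nM;
compound 3 `CN(C)Cc1ccc(NC(=O)Nc2ccc3ncnc(Nc4cccc(C(F)(F)F)c4)c3c2)cc1` gives 1030 nM.

Compound 3 gives the lowest number of the three and is therefore the strongest inhibitor here: the step of a 2.3-fold lower number from compound 1 to compound 3 (0.37 log units; beyond the scatter) and the step of a 3.9-fold lower number from compound 2 to compound 3 (0.59 log units; beyond the scatter) both lie beyond the scatter, while a 1.7-fold higher number from compound 1 to compound 2 (0.22 log units; within the scatter) does not. Among the compounds with values here, every step so far changes only the amine on the saturated chain carbon.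

Compound 4 `O=C(Nc1cccc(CN2CCCC2)c1)Nc1ccc2ncnc(Nc3cccc(C(F)(F)F)c3)c2c1` differs from compound 3 by 3-((pyrrolidin-1-yl)methyl)phenyl in place of 4-((dimethylamino)methyl)phenyl on an amide-type nitrogen. Two things change at once: the amine becomes a ring, and the substituted phenyl itself is renamed. The measured steps speak only to the first part, and there they show that the smallest amine, dimethylamino, gave the lowest number, while a ring amine, 4-methylpiperazin-1-yl, gave a higher one. Within the data shown here, for the second part there is no precedent at all. A modest rise in the number is therefore expected, with wide uncertainty, as a 2.1-fold higher number from compound 3 to compound 4 (0.33 log units; beyond the scatter). Compound 4 is estimated at 2200 nM, within a range from 700 nM to 7000 nM.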

Compound 4, half-maximal inhibitory concentration: 1230 nM
Estimate against measurement, compound 4: 1.8-fold (0.25 log units) above; measured number inside the range.
By their numbers in this assay, from the lowest: compounds 3, 4, 1 and 2 (each within the scatter of the next, the first and the last beyond it).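

In this assay, replacing 4-((dimethylamino)methyl)phenyl with 3-((pyrrolidin-1-yl)methyl)phenyl on the amide-type nitrogen gives a 1.2-fold higher number from compound 3 to compound 4 (0.08 log units; within the scatter), so this ring amine group matches the dimethylamino group within the scatter, something the 4-methylpiperazin-1-yl ring of compound 1 did not do. Against 4-((diethylamino)methyl)phenyl, the same group gives a 3.2-fold lower number from compound 2 to compound 4 (0.51 log units; beyond the scatter), a clear gain in strength. No measurement here accounts for either result.

Compound 4 changes the amine and the way it is carried on the phenyl together, so these compounds cannot separate the two effects; 3-((dimethylamino)methyl)phenyl or 4-((pyrrolidin-1-yl)methyl)phenyl would pull them apart. From the compounds shown here alone, how another ring amine, such as morpholine, would behave here also remains open.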